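Removing the acyl group from the amine nitrogen

The source may report more compounds than this note shows. Statements on the series, on what has been measured and on what is new or still open speak of the compounds shown alone.

The two measured analogues share one core. Compound 1 `N#CC1=C(NCC(=O)O)N(c2ccccc2)C(=O)N2CCCCC(N3CCCC3)C12` carries a carboxymethyl group on the amine nitrogen; in a functional assay on the whole organism (strain albino) for inhibition, with Rattus norvegicus as the target, read by paw edema, with stated times of 1 h and 3 h, at a dose of 20 mmol/kg by the intraperitoneal route (a higher number here means a stronger effect of the compound at the dose given, a lower number a weaker effect), compound 1 gives 89.2%. Compound 2 `N#CC1=C(NC(=O)c2ccccc2O)N(c2ccccc2)C(=O)N2CCCCC(N3CCCC3)C12` carries a (2-hydroxyphenyl)carbonyl group there instead, and in this assay compound 2 gives 65.4%, the lowest of the two numbers, with compound 1 its nearest neighbour a number 23.8 percentage points lower from compound 1 to compound 2 (beyond the scatter). Compound 3 `N#CC1=C(N)N(c2ccccc2)C(=O)N2CCCCC(N3CCCC3)C12` is not yet measured; it differs from compound 2 by hydrogen in place of (2-hydroxyphenyl)carbonyl on an amine nitrogen. Within the data shown here, the only step at hand is the exchange from compound 1 to compound 2, which lowered inhibition by a modest amount; no measured pair shows the bare amine. Compound 3 is expected to lie near or somewhat above compound 2, estimated at 70%, between 45% and 90%. The expected step from compound 2 to compound 3 is a number 4.6 percentage points higher from compound 2 to compound 3 (within the scatter).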

Compound 3, a percentage reported as inhibition, in the whole organism at one dose (the size of the read-out at that dose, not a potency): 90.1%
Estimate against measurement, compound 3: 20.1 percentage points below, outside the stated range (above it).
By their numbers in this assay, from the lowest: compound 2; then compounds 1 and 3 (each within the scatter of the next).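

In this assay, replacing the (2-hydroxyphenyl)carbonyl on the amine nitrogen with hydrogen gives a number 24.7 percentage points higher from compound 2 to compound 3 (beyond the scatter) and so ties the lower reading of compound 2 to this group rather than to the shared core. Replacing carboxymethyl with hydrogen at the same nitrogen gives a number 0.9 percentage points higher from compound 1 to compound 3 (within the scatter) and so shows that this level of inhibition at the dose given does not depend on a substituent there. Nothing at hand explains how the (2-hydroxyphenyl)carbonyl group lowers the reading.

From the compounds shown here alone, whether an acetyl group, or a benzoyl group without the hydroxyl, would also lower the reading stays open, so the part of the (2-hydroxyphenyl)carbonyl that matters remains unidentified. Also open, going by these compounds, is the effect of a methyl group or a longer chain ending in a carboxylic acid on this nitrogen.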